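This account rests on a few compounds, and the source may have more. Where it says the series, first, only, none or still open, it means among the compounds named here.

Of the compounds shown here, three sharing one core have been tested in a functional assay on the whole organism (strain Wistar) for inhibition, with Rattus norvegicus as the target, read by paw edema, with stated times of 60 min and 3 h, at a dose of 100 mg/kg by the oral route; on this read-out higher numbers stand for more inhibition at the one dose given (going by the name of the read-out) and lower numbers for less inhibition. Compound 1 `CCNC(=O)CC1CCc2cc(OC)c(OC)cc21` gives 26.1%; compound 2 `COc1cc2c(cc1OC)C(CC(=O)NC1CCCCC1)CC2` gives 49.3%; compound 3 `COc1cc2c(cc1OC)C(CC(=O)N1CCCC1)CC2` gives 26.1%. Among the compounds with values here, on these numbers compound 3 stands level with compound 1, the two together forming the lowest pair of the three, while the only change beyond the scatter is a number 23.2 percentage points lower from compound 2 to compound 3 (beyond the scatter).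

Compound 4 `COc1cc2c(cc1OC)C(CC(=O)NCCO)CC2` is the next step from compound 3. The structural change is (2-hydroxyethyl)amino in place of pyrrolidin-1-yl on a carbonyl carbon.

Within the data shown here, two measured steps bear on this place. Swapping the amide substituent between ethylamino and pyrrolidin-1-yl gave no change at the digits printed from compound 1 to compound 3 (within the scatter), whereas the larger cyclohexylamino group stood apart, with a number 23.2 percentage points lower from compound 2 to compound 3 (beyond the scatter). The (2-hydroxyethyl)amino group entering in compound 4 is an open-chain amine of similar size to the ethylamino of compound 1 rather than to the cyclohexylamino of compound 2, so a step of the kind seen from compound 1 to compound 3 seems the closer guide.

In this assay compound 4 is therefore expected to give 30%, within a range from 15% to 48%, which means an estimated a number 3.9 percentage points higher from compound 3 to compound 4 (within the scatter).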

Compound 4, a percentage reported as inhibition, in the whole organism at one dose (the size of the read-out at that dose, not a potency): 12.3%
For compound 4 the middle estimate is 17.7 percentage points above the measured one, and the stated range ends above it.
By their numbers in this assay, from the lowest: compound 4; then compounds 1 and 3 (each within the scatter of the next); then compound 2.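

In this assay, this amide position proves sensitive to a small edit: hydroxy in place of hydrogen on the ethyl chain gives a number 13.8 percentage points lower from compound 1 to compound 4 (beyond the scatter), and (2-hydroxyethyl)amino in place of pyrrolidin-1-yl gives a number 13.8 percentage points lower from compound 3 to compound 4 (beyond the scatter), whereas the earlier swap of ethylamino for pyrrolidin-1-yl showed no such separation. 2-Hydroxyethyl in place of cyclohexyl gives a number 37 percentage points lower from compound 2 to compound 4 (beyond the scatter), the widest step in the set, and leaves compound 4 lowest of the four. No measurement shown here accounts for the effect of the hydroxy group.

On these data alone, it remains open whether the drop is specific to the hydroxy group or would also follow a methoxy or an amine at the end of the chain. A longer chain such as 3-hydroxypropyl, or a phenyl in place of cyclohexyl, would also extend the picture.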